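Swapping a Pentan-3-yl for Oxolan-2-yl on the Core

A few compounds are considered here, and "the series" means these few. Any claim that something is new, unique, unknown or untested is made for them only; others in the source may bear on it.

Compound 1 `CCC(CC)Cn1c(Cc2cc(OC)c(OC)c(OC)c2)nc2c(N)ncnc21` gives 158000 nM.
Compound 2 `CCCCn1c(Cc2cc(OC)c(OC)c(OC)c2Cl)nc2c(N)ncnc21` gives 19100 nM.
Compound 3 `COCCn1c(Cc2cc(OC)c(OC)c(OC)c2)nc2c(N)nc(F)nc21` gives 64600 nM.

All three values come from a functional assay on MCF7 cells (Homo sapiens) for antiproliferative activity; a higher number here means a weaker inhibitor, a lower number a stronger inhibitor. Compound 1 stands highest of the three numbers; compound 3 is its nearest neighbour and compound 2 the furthest, both gaps lying beyond the scatter of this assay. Compound 4 `COc1cc(Cc2nc3c(N)ncnc3n2CC2CCCO2)cc(OC)c1OC` differs from compound 1 in one place: oxolan-2-yl in place of pentan-3-yl on a saturated chain carbon bound to an aromatic nitrogen. Within the data shown here, no measured pair here makes this same change, so its size is uncertain. The chain in compound 4 carries an oxygen, and compound 3, whose chain also carries an oxygen, gives a lower number than compound 1. A modest step toward a lower number is therefore expected, a 2.3-fold lower number from compound 1 to compound 4 (0.35 log units; beyond the scatter). Compound 4 is estimated at 70000 nM, between 25000 nM and 200000 nM.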

Compound 4, half-maximal inhibitory concentration: 91200 nM
For compound 4 the middle estimate is 1.3-fold (0.11 log units) below the measured one; the measured number falls inside the stated range.
By their numbers in this assay, from the lowest: compound 2; then compounds 3, 4 and 1 (each within the scatter of the next, the first and the last beyond it).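

In this assay, putting oxolan-2-yl in place of pentan-3-yl on a saturated chain carbon bound to an aromatic nitrogen gives a 1.7-fold lower number from compound 1 to compound 4 (0.24 log units; within the scatter), the first step read at this position with all else held equal. At this position, then, the change brings in a ring oxygen and a hydrogen-bond acceptor without separating the two compounds. Nothing available explains this result.

Going by these compounds, whether an amine, a carboxylic acid or a longer chain at this position would give a step beyond the scatter remains open. So does whether this same change would read alike on the core of compound 2 or compound 3.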